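The compounds below may be only part of what the source reports. "The series", "measured", "known", "first", "only" and "open" are said of these compounds alone.

Measured compounds:
compound 1 `Cc1nc2ccccc2nc1Oc1ccc(C(=O)N[C@@H](C)C(=O)O)cc1`, 22300 nM
compound 2 `Cc1nc2ccccc2nc1Oc1ccc(C(=O)N[C@@H](CC(C)C)C(=O)O)cc1`, 17300 nM
compound 3 `Cc1nc2cc(Cl)ccc2nc1Oc1ccc(C(=O)N[C@@H](C)C(=O)O)cc1`, 30000 nM

All three were run in a functional assay on HeLa cells (Homo sapiens) for antiproliferative activity, read by MTT assay, with a stated time of 48 h; a lower number here means a stronger inhibitor, a higher number a weaker inhibitor. Compound 2 differs from compound 1 by isopropyl in place of hydrogen on a saturated chain carbon, two bonds along the chain from an amide-type nitrogen and a carbonyl carbon, and the two values give a 1.3-fold lower number from compound 1 to compound 2 (0.11 log units; within the scatter). Compound 3 differs from compound 1 by chloro in place of hydrogen on an aromatic carbon, a change that made a 1.3-fold higher number from compound 1 to compound 3 (0.13 log units; within the scatter). The unmeasured compound 4 `Cc1nc2ccc(Cl)cc2nc1Oc1ccc(C(=O)N[C@@H](CC(C)C)C(=O)O)cc1` carries the same change on the core of compound 2: chloro in place of hydrogen on an aromatic carbon. Among the measured compounds shown here, the place of the entering chloro reads the same in both cases, so this is the same change, occurring twice in all among the compounds here; its one measured instance stayed within the scatter. In this assay a step of like size is expected for compound 4, a 1.3-fold higher number from compound 2 to compound 4 (0.10 log units; within the scatter), because a 1.3-fold higher number from compound 1 to compound 3 (0.13 log units; within the scatter) went no further. For the measured compounds named here, no step between compound 2 and compound 3 is broken down here; their values alone show a gap within the scatter. On that basis compound 4 is estimated at 22000 nM, with a range from 12000 nM to 40000 nM.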

Compound 4, half-maximal inhibitory concentration: 16400 nM
Compound 4: middle estimate off by 1.3-fold (0.13 log units), on the high side; measured number inside the range.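

In this assay, chloro in place of hydrogen on an aromatic carbon gives a 1.1-fold lower number from compound 2 to compound 4 (0.02 log units; within the scatter), and the two instances of this change agree: the same change on two cores in this assay, a 1.3-fold higher number (0.13 log units; within the scatter) from compound 1 to compound 3 and a 1.1-fold lower number (0.02 log units; within the scatter) from compound 2 to compound 4, 1.4-fold (0.15 log units) apart, within the scatter of two such steps On these two cores, the change carries across with no step beyond the scatter, and the isopropyl difference between the cores does not alter that reading. Since neither step leaves the scatter, the agreement shows only that both are small; it does not show that chloro has a real effect in either direction, or that a change with a larger step would carry from one core to another equally well.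

The compounds shown leave open whether a different group on that aromatic carbon, such as methoxy, trifluoromethyl or an amine, would give a step beyond the scatter. Also open, from the compounds shown here alone, is whether a methyl ester or a primary amide in place of the carboxylic acid would do so on either core.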